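The source may report more compounds than this note shows. Statements on the series, on what has been measured and on what is new or still open speak of the compounds shown alone.

Measured compounds in an assay on HEK293 cells for displacement of a labelled ligand from Melanocortin receptor 4 (Homo sapiens); a higher number here means a weaker inhibitor, a lower number a stronger inhibitor:
compound 1, `CC(C)C[C@H](N)c1cc(C(F)(F)F)ccc1N1CCN(C(=O)[C@H](C)Cc2ccc(Cl)cc2)CC1` — compound 1 gives 31 nM
compound 2, `CC(C)C[C@H](N)c1cc(C(F)(F)F)ccc1N1CCN(C(=O)CCC2CCCCC2)CC1` — compound 2 gives 5700 nM
compound 3, `COc1ccc(CC(C)C(=O)N2CCN(c3ccc(C(F)(F)F)cc3[C@@H](N)CC(C)C)CC2)cc1` — compound 3 gives 120 nM

Compound 3 stands second of the three numbers in this assay: it sits nearer to compound 1, being a 3.9-fold higher number from compound 1 to compound 3 (0.59 log units; beyond the scatter), and far from compound 2, the step being a 48-fold lower number from compound 2 to compound 3 (1.68 log units; beyond the scatter). The piece now turns to compound 4, `Cc1ccc(CC(C)C(=O)N2CCN(c3ccc(C(F)(F)F)cc3[C@@H](N)CC(C)C)CC2)cc1C`, which differs from compound 3 in one place: 3,4-dimethylphenyl in place of 4-methoxyphenyl on a saturated chain carbon, two bonds along the chain from a carbonyl carbon.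

Among the compounds with values here, two measured steps bear on this change, but only loosely. The large step of a 48-fold lower number from compound 2 to compound 3 (1.68 log units; beyond the scatter) shows that keeping a six-membered aromatic ring in this position matters greatly, and compound 4 keeps it. The modest step of a 3.9-fold higher number from compound 1 to compound 3 (0.59 log units; beyond the scatter) shows that exchanging one substituent on that ring for another moves the number by a modest amount, with the methoxy-bearing compound 3 giving the higher number. Within the data shown here, no measured pair shows the methoxy to dimethyl exchange itself. Compound 4 is therefore expected to give a number near that of compound 3 or somewhat lower, an expected step of a 1.7-fold lower number from compound 3 to compound 4 (0.23 log units; within the scatter). The estimate for compound 4 is 70 nM, with a range from 20 nM to 250 nM.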

Compound 4, inhibition constant: 240 nM
The estimate for compound 4 lay 3.4-fold (0.54 log units) below the measured number; measured number inside the range.
By their numbers in this assay, from the lowest: compound 1; then compounds 3 and 4 (each within the scatter of the next); then compound 2.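

In this assay, exchanging 4-methoxyphenyl for 3,4-dimethylphenyl, which takes away the group's one hydrogen-bond acceptor, leaves the two compounds indistinguishable (a 2.0-fold higher number from compound 3 to compound 4 (0.30 log units; within the scatter)), so the methoxy oxygen is not shown to be needed at this position. The dimethyl ring also stays well clear of the cyclohexyl compound (a 24-fold lower number from compound 2 to compound 4 (1.38 log units; beyond the scatter)) but does not match the chloro-bearing compound (a 7.7-fold higher number from compound 1 to compound 4 (0.89 log units; beyond the scatter)), which leaves compound 1 with the lowest number of the set. No measurement given here accounts for these differences.

The compounds shown leave open how a phenyl ring carrying a single methyl would compare, and so whether either methyl of compound 4 matters on its own. They also leave open whether a ring carrying an amine or a carboxylic acid would hold the number near that of compound 3.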